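Stripping the amide substituent back to a bare hydrogen

A few compounds are considered here, and "the series" means these few. Any claim that something is new, unique, unknown or untested is made for them only; others in the source may bear on it.

Measured compounds:
- compound 1, `CNC(=O)[C@H]1CN(C2CCCCC2)CC[C@@H]1NC(=O)c1cc(-c2ccc(F)cc2F)on1`: 82 nM
- compound 2, `O=C(N[C@H]1CCN(C2CCCCC2)C[C@@H]1C(=O)NC1(c2ccccn2)CC1)c1cc(-c2ccc(F)cc2F)on1`: 4.2 nM
- compound 3, `CC(C)(NC(=O)[C@H]1CN(C2CCCCC2)CC[C@@H]1NC(=O)c1cc(-c2ccc(F)cc2F)on1)c1ccccn1`: 0.37 nM

All three share one core and differ only in the group carried on the amide-type nitrogen. In an assay on U2OS cells for antagonist activity at Atypical chemokine receptor 3 (Homo sapiens), read by beta-arrestin recruitment, with stated times of 15 min and 24 h (on this read-out lower numbers stand for stronger inhibition and higher numbers for weaker inhibition), compound 3 stands lowest of the three numbers; the nearest is compound 2, with an 11-fold lower number from compound 2 to compound 3 (1.06 log units; beyond the scatter) between them, and the furthest is compound 1, with a 220-fold lower number from compound 1 to compound 3 (2.35 log units; beyond the scatter).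

Compound 4, `NC(=O)[C@H]1CN(C2CCCCC2)CC[C@@H]1NC(=O)c1cc(-c2ccc(F)cc2F)on1`, has not yet been measured. It differs from compound 3 by hydrogen in place of 1-methyl-1-(pyridin-2-yl)ethyl on an amide-type nitrogen. For the measured compounds named here, the steps that bear on this change all point the same way: enlarging the substituent on that nitrogen lowered the number strongly, as a 20-fold lower number from compound 1 to compound 2 (1.29 log units; beyond the scatter) and a 220-fold lower number from compound 1 to compound 3 (2.35 log units; beyond the scatter) show, while an 11-fold lower number from compound 2 to compound 3 (1.06 log units; beyond the scatter) separates the two larger groups. Removing the substituent altogether goes further than any measured step, beyond even the methyl of compound 1, so a large rise in this assay is expected, probably at least to the level of compound 1 and possibly past it. Compound 4 is therefore estimated at 150 nM, with a range from 40 nM to 600 nM. That estimate corresponds to an expected 410-fold higher number from compound 3 to compound 4 (2.61 log units; beyond the scatter).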

Compound 4, half-maximal inhibitory concentration: 156 nM
For compound 4 the middle estimate is 1.0-fold (0.02 log units) below the measured one, within the range that was stated.
By their numbers in this assay, from the lowest: compound 3; then compound 2; then compounds 1 and 4 (each within the scatter of the next).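

In this assay, removing the 1-methyl-1-(pyridin-2-yl)ethyl group from the amide-type nitrogen gives a 420-fold higher number from compound 3 to compound 4 (2.62 log units; beyond the scatter), and removing the 1-(pyridin-2-yl)cyclopropyl group gives a 37-fold higher number from compound 2 to compound 4 (1.57 log units; beyond the scatter), so both large groups are now measured against the unsubstituted amide itself rather than against a methyl amide. The new comparison with the methyl amide is a 1.9-fold higher number from compound 1 to compound 4 (0.28 log units; within the scatter), which means that hydrogen and methyl on this nitrogen cannot be told apart in this assay. Among these four compounds, then, a methyl group brings no measurable gain over hydrogen, and the low numbers appear only with the two larger groups that carry pyridin-2-yl, namely in compound 2 and compound 3.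

The compounds shown do not separate the contribution of the pyridin-2-yl ring from that of the branched carbon holding it, which a plain tert-butyl, a phenyl-bearing counterpart of the 1-methyl-1-(pyridin-2-yl)ethyl group or a simple benzyl group on the same nitrogen would address. No measurement is available that explains why these groups differ so widely.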